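This account rests on a few compounds, and the source may have more. Where it says the series, first, only, none or still open, it means among the compounds named here.

Measured compounds:
compound 1, `CC(=O)NCc1cccc(Cn2nc(NS(=O)(=O)c3ccc(Cl)s3)c3c(CO)cccc32)c1`, 1000 nM in an assay on isolated protein (blood) for antagonist activity at C-C chemokine receptor type 4 (Homo sapiens), read by flow cytometry, with a stated time of 30 min; a higher number here means weaker binding, a lower number tighter binding
compound 2, `COc1cccc2c1c(NS(=O)(=O)c1ccc(Cl)s1)nn2Cc1cccc(CNC(=O)C2COC2)c1`, 1000 nM in this assay

Going by the values given here, compound 1 and compound 2 share a core and differ at two places, so no single step links them; their values simply show that compound 2 stands level with compound 1 in this assay, the two numbers lying within the usual scatter of each other.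

Compound 3, `COc1cccc2c1c(NS(=O)(=O)c1ccc(Cl)s1)nn2Cc1cccc(CNC(=O)C2CCCO2)c1`, has not yet been measured. It differs from compound 2 in one place: oxolan-2-yl in place of oxetan-3-yl on a carbonyl carbon. Among the compounds with values here, the unmeasured compound differs from compound 2 only at this point of the chain, and no measured pair shows what such a change does in this assay. With nothing in the present data to suggest otherwise, the step from compound 2 to compound 3 is expected to be small, no change at the digits printed from compound 2 to compound 3 (within the scatter), in no particular direction beyond the scatter. Compound 3 is therefore estimated to give about 1000 nM in this assay, within a range of 400 nM to 2500 nM.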

Compound 3, dissociation constant: 794 nM
Compound 3: middle estimate off by 1.3-fold (0.10 log units), on the high side, within the range that was stated.
By their numbers in this assay, from the lowest: compounds 3, 1 and 2 (each within the scatter of the next).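

In this assay, the exchange of oxetan-3-yl for oxolan-2-yl on a carbonyl carbon gives a 1.3-fold lower number from compound 2 to compound 3 (0.10 log units; within the scatter). This is the first single-place comparison among these compounds, and it shows that, at this position, a five-membered non-aromatic ring and a four-membered one cannot be told apart in this measurement, although the group entering is one heavy atom, a carbon, larger than the one leaving. Nothing available bears on why the two groups read alike.

Still open, as far as these compounds go, is whether a group of another kind at this position, such as cyclopentyl with no ring oxygen, a piperidine with its ring amine, or an open methoxymethyl chain, would move the number beyond the scatter. Also open, from the compounds shown here alone, is whether oxolan-2-yl would read the same way on the core of compound 1.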